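The source may hold more compounds than are shown below. What is called first, only, known or untested is meant among the compounds shown, and "the series" means these compounds.

Of the compounds shown here, three have been tested so far in an assay on isolated protein for inhibition of Calpain-1 catalytic subunit (Sus scrofa), read by FRET; on this read-out lower numbers stand for stronger inhibition and higher numbers for weaker inhibition. Compound 1, `O=C(O)/C(S)=C/c1ccc(F)cc1`, carries the shared acid arm on a single six-membered aromatic ring bearing fluoro; in this assay compound 1 gives 6900 nM. Compound 2, `O=C(O)/C(S)=C/c1c[nH]c2ccc(I)cc12`, places the same arm on a fused system of two rings that carries iodo, and in this assay compound 2 gives 100 nM. Compound 3, `O=C(O)/C(S)=C/c1c[nH]c2c(Cl)cccc12`, keeps the fused system but carries chloro, and in this assay compound 3 gives 10 nM. Compound 3 therefore stands lowest of the three numbers; its nearest neighbour is compound 2, whose number is higher by an amount beyond the usual scatter, and compound 1 lies furthest away, also well beyond the scatter.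

The step now considered leads to compound 4, `O=C(O)/C(S)=C/c1c[nH]c2c(F)cccc12`. (fluoro in place of chloro on an aromatic carbon). Among the compounds with values here, no pair of measured compounds differs in this one place alone, so the size of this kind of step is not known from the data. Because compound 3 sits at 10 nM while compound 2 with iodo sits at 100 nM, a change of one halogen on the fused system is expected to shift the number only modestly, most likely upward. The estimate for compound 4 in this assay is 25 nM, with a plausible range from 8 nM to 80 nM. This estimate means an expected step of a 2.5-fold higher number from compound 3 to compound 4 (0.40 log units; beyond the scatter), a mild loss lying near the edge of the scatter.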

Compound 4, half-maximal inhibitory concentration: 120 nM
Estimate against measurement, compound 4: 4.8-fold (0.68 log units) below, and the stated range ends below it.
By their numbers in this assay, from the lowest: compound 3; then compounds 2 and 4 (each within the scatter of the next); then compound 1.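

In this assay, within the data shown here, fluoro in place of chloro on this aromatic carbon gives a 12-fold higher number from compound 3 to compound 4 (1.08 log units; beyond the scatter), the first step that changes one place alone. The change is small by the counts: one heavy atom replaces another, with no ring, hydrogen-bond donor, hydrogen-bond acceptor or net charge entering or leaving, yet the number moves well beyond the usual scatter, so at this position one halogen cannot simply stand in for the other. Nothing shown explains why compound 3 has the lower number.

As far as these compounds go, with only chloro and fluoro compared at this position, it remains open whether bromo, a methyl group, a methoxy group or an amine on the same carbon would give a number close to that of compound 3 or of compound 4. Among these compounds, it is also open whether the same exchange of chloro for fluoro on another carbon of this ring, or on the single ring of compound 1, would produce a step of similar size.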